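Chloro in Place of Bromo on the Shared Core

This account rests on a few compounds, and the source may have more. Where it says the series, first, only, none or still open, it means among the compounds named here.

Of the compounds shown here, two have been tested so far. In a toxicity assay on the whole organism with Rattus norvegicus as the target, at a dose of 400 mg/kg by the oral route (a lower number here means a weaker effect, a higher number a stronger effect of the compound at the dose given), compound 1 `COc1ccc(OCC2=NCCO2)cc1` gives 90%, and in this assay compound 2 `Brc1ccccc1OCC1=NCCO1` gives 100%. Compound 2 thus holds the larger of the two numbers, yet its distance from compound 1 lies within the usual scatter, so the two cannot be told apart. Compound 3 `Clc1ccccc1OCC1=NCCO1` differs from compound 2 by chloro in place of bromo on an aromatic carbon. Among the compounds with values here, no measured pair shows what such a change does here; the step of a number 10 percentage points lower from compound 2 to compound 3 (within the scatter) is expected to be small, none beyond the scatter. Compound 3 is estimated to give 90%, between 70% and 100%.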

Compound 3, a percentage reported as activity, at one dose (the size of the read-out at that dose, not a potency): 60%
Compound 3: middle estimate off by 30 percentage points, on the high side; the measured number lies below the stated range.
By their numbers in this assay, from the lowest: compound 3; then compounds 1 and 2 (each within the scatter of the next).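

In this assay, chloro in place of bromo brings a number 40 percentage points lower from compound 2 to compound 3 (beyond the scatter), so the exchange of a single atom is not a silent change here. This aromatic carbon, ortho to a group of 7 heavy atoms, thus responds strongly to which halogen it carries, although the counts of heavy atoms, donors and acceptors and the net charge stay the same. No measurement at hand accounts for the size of this step.

From the compounds shown here alone, what fluoro, methyl or an amine on this carbon would give stays open. So does whether the same exchange elsewhere on the ring would give a step of this size.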